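The compounds below may be only part of what the source reports. "The series", "measured", "known", "first", "only" and "open" are said of these compounds alone.

Of the compounds shown here, three built on one shared core have been tested in a functional assay on KM12 cells (Homo sapiens) for cytotoxicity, read by sulforhodamine B assay, with a stated time of 48 h; on this read-out higher numbers stand for lower toxicity in this test and lower numbers for higher toxicity in this test. Compound 1 `ClCc1ccccc1Cn1cnc2c(Cl)nc(Cl)nc21` gives 5880 nM, and compound 3 `ClCc1ccc(Cn2cnc3c(Cl)nc(Cl)nc32)cc1` gives 5750 nM. Compound 2 `ClCc1ccccc1Cn1cnc2c(Cl)ncnc21` gives 66100 nM, the highest number of the three. Going by the values given here, the only measured step leading to it, an 11-fold higher number from compound 1 to compound 2 (1.05 log units; beyond the scatter), shows that removing a chloro group from this core pushes the number up sharply, meaning far weaker cell killing.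

Compound 4 `Nc1nc(Cl)c2ncn(Cc3ccccc3CCl)c2n1` is the next compound to be examined. It differs from compound 2 by amino in place of hydrogen on an aromatic carbon. Among the compounds with values here, no measured step places an amino group anywhere on this core, so the only guide is an 11-fold higher number from compound 1 to compound 2 (1.05 log units; beyond the scatter), which concerns the same carbon but a different group; it tells that this position can move the number strongly, without telling which way an amino group will move it. A modest step toward a lower number than compound 2 is expected, a 2.2-fold lower number from compound 2 to compound 4 (0.34 log units; beyond the scatter), with wide uncertainty. The estimated value for compound 4 in this assay is 30000 nM, with a range from 8000 nM to 100000 nM.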

Compound 4, concentration lethal to 50% of the cells: 97200 nM
Estimate against measurement, compound 4: 3.2-fold (0.51 log units) below, within the range that was stated.
By their numbers in this assay, from the lowest: compounds 3 and 1 (each within the scatter of the next); then compounds 2 and 4 (each within the scatter of the next).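

In this assay the step to the amino compound reads a 1.5-fold higher number from compound 2 to compound 4 (0.17 log units; within the scatter), so at this carbon amino and hydrogen cannot be told apart in this test. Set against the chloro group of compound 1, the same carbon gives a 17-fold higher number from compound 1 to compound 4 (1.22 log units; beyond the scatter), which is large and matches the picture from an 11-fold higher number from compound 1 to compound 2 (1.05 log units; beyond the scatter): among compounds 1, 2 and 4, only the chloro compound carries the low number, and adding amino does not restore it. No measurement here explains why chloro stands apart from the other two groups at this carbon.

Still open, from the compounds shown here alone, is where other groups on this carbon, such as fluoro, methoxy or a methylamino group, would fall. Also open, going by these compounds, is whether amino in place of chloro gives a similar step on the core of compound 3.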